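The source may hold more compounds than are shown below. What is called first, only, known or untested is meant among the compounds shown, and "the series" means these compounds.

The series shares one core in which a saturated ring carbon carries an aryl group; compound 1 `COc1cc(C2=NN(C(C)=O)C(c3cccc(F)c3)O2)cc(OC)c1OC`, compound 2 `COc1cc(C2=NN(C(C)=O)C(c3ccccc3F)O2)cc(OC)c1OC` and compound 3 `COc1cc(C2=NN(C(C)=O)C(c3cc(Cl)cc(Cl)c3)O2)cc(OC)c1OC` differ only in that aryl group. In a functional assay on BGC-823 cells (Homo sapiens) for antiproliferative activity, read by MTT assay, tested at 5 uM (a higher number here means a stronger effect of the compound at the concentration tested, a lower number a weaker effect), compound 1 gives 37.7%, compound 2 gives 32.8% and compound 3 gives 6.6%. The step of a number 4.9 percentage points lower from compound 1 to compound 2 (within the scatter) stays within the scatter, so the two fluorophenyl compounds cannot be ordered. Compound 3 stands lowest of the three numbers: a number 31.1 percentage points lower from compound 1 to compound 3 (beyond the scatter) and a number 26.2 percentage points lower from compound 2 to compound 3 (beyond the scatter), both beyond the scatter, place the 3,5-dichlorophenyl compound clearly below both fluorophenyl compounds.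

Compound 4 `COc1cc(C2=NN(C(C)=O)C(c3ccc(Cl)c([N+](=O)[O-])c3)O2)cc(OC)c1OC` is not yet measured. It differs from compound 3 by 4-chloro-3-nitrophenyl in place of 3,5-dichlorophenyl on a saturated ring carbon. Among the measured compounds shown here, the two steps into compound 3 are the only ones that bear on this change: both show that the 3,5-dichlorophenyl is the weakest aryl group measured, but a 4-chloro-3-nitrophenyl is not among the measured groups, and no measured step involves a nitro group, so the direction rests on the dichloro pattern alone. The expectation for compound 4 in this assay is a rise of a number 15.4 percentage points higher from compound 3 to compound 4 (beyond the scatter), beyond the scatter but short of the fluorophenyl level. Compound 4 is estimated at 22%, between 5% and 42%.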

Compound 4, a percentage reported as inhibition, at one concentration (the size of the read-out at that concentration, not a potency): 0%
Estimate against measurement, compound 4: 22 percentage points above, outside the stated range (below it).
By their numbers in this assay, from the lowest: compounds 4 and 3 (each within the scatter of the next); then compounds 2 and 1 (each within the scatter of the next).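

Among the compounds shown here, at this saturated ring carbon, the 4-chloro-3-nitrophenyl group, the only aryl group here with a nitro group, does not separate from the 3,5-dichlorophenyl group in this assay: the step of a number 6.6 percentage points lower from compound 3 to compound 4 (within the scatter) leaves the two unordered. For the compounds shown here, the steps of a number 32.8 percentage points lower from compound 2 to compound 4 (beyond the scatter) and a number 37.7 percentage points lower from compound 1 to compound 4 (beyond the scatter) place this second chlorine-bearing aryl group clearly below both fluorophenyl compounds, so across these four compounds the two chlorine-bearing aryl groups form a low pair and the two fluorophenyl groups a higher pair, with no compound going against that split. No measurement on these compounds speaks to the reason for this split.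

The compounds shown leave open whether a phenyl with a nitro group and no chlorine, a phenyl with a single chlorine or an unsubstituted phenyl would read with the fluorophenyl pair or with compound 3 and compound 4. Also open, from the compounds shown here alone, is how an amine or a carboxylic acid on this aryl group would read in this assay.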